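Adding hydroxy to compound 2: a working estimate

The compounds below may be only part of what the source reports. "The series", "measured", "known", "first", "only" and "open" are said of these compounds alone.

Measured in a functional assay on MGC-803 cells (Homo sapiens) for antiproliferative activity, read by MTT assay, with a stated time of 72 h (on this read-out lower numbers stand for stronger inhibition and higher numbers for weaker inhibition), as follows:
compound 1 `Cc1ccccc1-n1nc(-c2ccccc2)nc1CNc1ccc(C(=O)NO)cc1` gives 12300 nM
compound 2 `COc1ccc(-n2nc(-c3ccccc3)nc2CNc2ccc(C(=O)NO)cc2)cc1` gives 7050 nM
compound 3 `COc1ccc(-c2nc(CNc3ccc(C(=O)NO)cc3)n(-c3ccccc3)n2)cc1` gives > 20000 nM as a limit of the assay

Within the data shown here, compound 2 and compound 1 hold the only two numbers, and they are separated by a 1.7-fold lower number from compound 1 to compound 2 (0.24 log units; within the scatter) in this comparison. Compound 3 stands at the limit of > 20000 nM in this assay, at which 1 of the 3 values shown sits, and gives no number. Compound 4 `COc1ccc(-n2nc(-c3ccc(O)cc3)nc2CNc2ccc(C(=O)NO)cc2)cc1` follows from compound 2 by hydroxy in place of hydrogen on an aromatic carbon with hydroxy in place of hydrogen on an aromatic carbon, phenyl to 4-hydroxyphenyl. Among the measured compounds shown here, the one measured step, a 1.7-fold lower number from compound 1 to compound 2 (0.24 log units; within the scatter) on an aromatic nitrogen, lies elsewhere and bears only indirectly. Compound 3 carries methoxy on the ring changed here and reaches only a limit. No step beyond the scatter is expected in this assay and the estimated 1.3-fold higher number from compound 2 to compound 4 (0.11 log units; within the scatter) leans slightly upward. For compound 4 the estimate is 9000 nM with an expected range from 3000 nM to 20000 nM at the upper end.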

Compound 4, half-maximal inhibitory concentration: > 20000 nM
Compound 4 was reported as a limit (the forecaster's own chance of this, stated with the estimate: 15%); at least 2.2-fold (0.34 log units) between middle value and limit.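

In this assay, among these compounds, phenyl to 4-hydroxyphenyl gives an at least 2.8-fold higher number from compound 2 to compound 4 (0.45 log units; beyond the scatter), the first step that lies beyond the scatter. At this position, para to a large group, a single hydroxy is therefore enough to weaken inhibition, whereas the change on the aromatic nitrogen in the earlier step stayed within the scatter. Compound 4 gives no number, so the step has only a lower bound, set by the limit: the limit of > 20000 nM in this assay, at which 2 of the 4 values shown sit.

Going by these compounds, whether an amine, a methyl or a carboxylic acid in the same place also raises the number stays open. On these data alone, how much weaker compound 4 really is also stays open.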